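The source may report more compounds than this note shows. Statements on the series, on what has been measured and on what is new or still open speak of the compounds shown alone.

Compounds measured so far:
compound 1, `Oc1ccc(-c2cc(-c3cccs3)cc(-c3cccc(O)c3)n2)cc1`, 1770 nM
compound 2, `Oc1ccc(-c2cc(-c3ccsc3)cc(-c3cccc(O)c3)n2)cc1`, 1180 nM
compound 3, `Oc1cccc(-c2cc(-c3ccoc3)cc(-c3ccccc3O)n2)c1`, > 50000 nM

Compound 1 and compound 2 differ only in the five-membered ring, and a 1.5-fold lower number from compound 1 to compound 2 (0.18 log units; within the scatter). For compound 3 the assay reports only a limit, (the limit of > 50000 nM in this assay, at which 1 of the 3 values shown sits), so no number stands for it and it cannot be ranked against compound 1 or compound 2 beyond saying that its limit lies far from their values.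

Compound 4, `Oc1ccc(-c2cc(-c3ccoc3)cc(-c3cccc(O)c3)n2)cc1`, is yet to be measured in a functional assay on HCT-15 cells (Homo sapiens) for cytotoxicity, read by CCK-8 assay; on this read-out lower numbers stand for stronger inhibition and higher numbers for weaker inhibition. It differs from compound 3 by 4-hydroxyphenyl in place of 2-hydroxyphenyl on an aromatic carbon. Within the data shown here, no measured step changes this group, so the one measured step, from compound 1 to compound 2, does not bear on it directly. What can be said is that compound 1 and compound 2 carry the same 4-hydroxyphenyl and 3-hydroxyphenyl arrangement that compound 4 carries, and both give numbers in the low-micromolar region. Compound 4 is therefore expected to leave the limit and fall near those two, with the step from compound 3 to compound 4 being an at least 20-fold lower number from compound 3 to compound 4 (1.30 log units; beyond the scatter). Compound 4 is estimated at 2500 nM, with a range from 800 nM to 10000 nM.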

Compound 4, half-maximal inhibitory concentration: 930 nM
For compound 4 the middle estimate is 2.7-fold (0.43 log units) above the measured one; the range from low to high includes it.
By their numbers in this assay, from the lowest: compounds 4, 2 and 1 (each within the scatter of the next). At a limit, above all of these: compound 3.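

In this assay, 4-hydroxyphenyl in place of 2-hydroxyphenyl next to the ring nitrogen, with the same atoms joined differently, gives an at least 53-fold lower number from compound 3 to compound 4 (1.73 log units; beyond the scatter), so for this pair the attachment of the hydroxyl on this ring separates a low-micromolar compound from an inactive one at the tested range. Compound 3 stands at a limit and not at a number: the limit of > 50000 nM in this assay, at which 1 of the 4 values shown sits. With 4-hydroxyphenyl in place, the five-membered ring does not separate the compounds, as furan-3-yl gives a 1.3-fold lower number from compound 2 to compound 4 (0.10 log units; within the scatter) and a 1.9-fold lower number from compound 1 to compound 4 (0.28 log units; within the scatter).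

On these data alone, the full size of the step from the 2-hydroxyphenyl compound stays open, as its upper end is not defined. Also open, as far as these compounds go, is whether 4-methoxyphenyl or 4-aminophenyl at this position would keep numbers like those of compound 4, which would test whether the hydroxyl itself is needed.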